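A few compounds are considered here, and "the series" means these few. Any claim that something is new, unique, unknown or untested is made for them only; others in the source may bear on it.

Measured so far:
- compound 1 `Nc1nc(N)c2cc(CSC(=S)N3CCN(c4ccc(F)cc4)CC3)ccc2n1`: 1920 nM
- compound 2 `Nc1nc(N)c2cc(CSC(=S)N3CCN(c4ccccc4F)CC3)ccc2n1`: 4840 nM

In a functional assay on MCF7 cells (Homo sapiens) for antiproliferative activity, read by MTT assay, with a stated time of 72 h (a lower number here means a stronger inhibitor, a higher number a weaker inhibitor), compound 2 gives 4840 nM, the higher of the two numbers and so the weaker result. Going by the values given here, its only neighbour is compound 1, and the gap between them is a 2.5-fold higher number from compound 1 to compound 2 (0.40 log units; beyond the scatter). The next compound is compound 3 `Nc1nc(N)c2cc(CSC(=S)N3CCN(c4ccccc4[N+](=O)[O-])CC3)ccc2n1`, which keeps the shared core and the 2-substituted phenyl of compound 2. The change is nitro in place of fluoro on an aromatic carbon, ortho to a large group.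

Among the compounds with values here, no measured compound carries a nitro group, so no step shows this replacement directly. Within the data shown here, the one available guide is a 2.5-fold higher number from compound 1 to compound 2 (0.40 log units; beyond the scatter), a modest step that exchanged 4-fluorophenyl for 2-fluorophenyl. It suggests that a change on this phenyl group can shift the number modestly, but it does not give a direction for the new group. A step of about that size in either direction is therefore possible, and no clear step beyond the scatter is expected. The expected step is a 1.2-fold lower number from compound 2 to compound 3 (0.08 log units; within the scatter). For compound 3 the estimated value is 4000 nM, with an expected range from 1500 nM to 11000 nM.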

Compound 3, half-maximal inhibitory concentration: 4350 nM
For compound 3 the middle estimate is 1.1-fold (0.04 log units) below the measured one; the measured number falls inside the stated range.
By their numbers in this assay, from the lowest: compound 1; then compounds 3 and 2 (each within the scatter of the next).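

In this assay, the step of a 1.1-fold lower number from compound 2 to compound 3 (0.05 log units; within the scatter) shows that, ortho to a large group on this phenyl ring, nitro and fluoro cannot be told apart, although nitro brings 3 heavy atoms and 2 hydrogen-bond acceptors where fluoro brings 1 heavy atom and no acceptor. The step of a 2.3-fold higher number from compound 1 to compound 3 (0.36 log units; beyond the scatter) is modest but beyond the scatter, so compound 3 joins compound 2 on the same side of compound 1, and both compounds with a 2-substituted phenyl group give higher numbers than the 4-fluorophenyl compound, with none of the three going against this. Nothing measured on these compounds offers a reason for either step.

Still open, as far as these compounds go, is whether an amine or a carboxylic acid at this place would also match fluoro and nitro, or would move the number beyond the scatter. From the compounds shown here alone, it is also open whether a 4-nitrophenyl group would match the 4-fluorophenyl group of compound 1, which would show whether the place of the substituent matters more than its identity.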